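Methoxy in place of methyl: compound 3 to compound 4

A few compounds are considered here, and "the series" means these few. Any claim that something is new, unique, unknown or untested is made for them only; others in the source may bear on it.

Measured in a physicochemical assay for solubility, read by HPLC, in phosphate buffer, with a stated time of 16 h, at pH 6.8; a lower number here means a less soluble compound, a higher number a more soluble compound
compound 1 `COc1ccc([C@H](C)NC(=O)Cn2nnc3ccccc3c2=O)cc1` gives 15000 nM
compound 2 `Cc1ccc([C@H](C)NC(=O)Cn2nnc3ccccc3c2=O)cn1` gives 9800 nM
compound 3 `Cc1ccc([C@H](C)NC(=O)Cn2nnc3ccccc3c2=O)c(C)c1` gives 2700 nM

Compound 3 stands lowest of the three. The two measured steps that reach it are a 5.6-fold lower number from compound 1 to compound 3 (0.74 log units; beyond the scatter) and a 3.6-fold lower number from compound 2 to compound 3 (0.56 log units; beyond the scatter) and both are modest. The remaining step, a 1.5-fold lower number from compound 1 to compound 2 (0.18 log units; within the scatter), says little here.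

Compound 4 `COc1cc(C)ccc1[C@H](C)NC(=O)Cn1nnc2ccccc2c1=O` is still unmeasured and carries methoxy in place of methyl on an aromatic carbon, ortho to a large group and meta to a methyl group (methoxy in place of methyl on an aromatic carbon). Within the data shown here, no measured step makes this exact exchange. Among the measured compounds only compound 1 carries a methoxy, as 4-methoxyphenyl, and a 5.6-fold lower number from compound 1 to compound 3 (0.74 log units; beyond the scatter) involves more than this one exchange, so it only loosely bounds the size expected.

In this assay the expected change is a 1.5-fold higher number from compound 3 to compound 4 (0.17 log units; within the scatter) and this small upward step may well stay within the scatter. For compound 4 the estimated solubility is 4000 nM with an expected range from 1500 nM to 11000 nM at its upper end.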

Compound 4, solubility: 6900 nM
Estimate against measurement, compound 4: 1.7-fold (0.24 log units) below; measured number inside the range.
By their numbers in this assay, from the lowest: compound 3; then compounds 4, 2 and 1 (each within the scatter of the next, the first and the last beyond it).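

Among these compounds, compound 3 and compound 4 give the first step that changes a single substituent rather than the whole aryl group. In this assay, methoxy in place of methyl on an aromatic carbon, ortho to a large group and meta to a methyl group, gives a 2.6-fold higher number from compound 3 to compound 4 (0.41 log units; beyond the scatter), so this one exchange alone produces a step beyond the scatter. Nothing available on these compounds accounts for the step.

The compounds shown leave open whether an ethoxy, a hydroxyl or an amine on this same aromatic carbon would give a step of similar size and direction. They also leave open whether the same methoxy-for-methyl exchange would give a comparable step at the remaining methyl group.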